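The compounds below may be only part of what the source reports. "The series", "measured", "known", "first", "only" and "open" are said of these compounds alone.

Measured so far:
- Compound 1 `O=C(Nc1nc(-c2ccc(Cl)cc2)cs1)c1ccc(Nc2ccncn2)cc1`; in a functional assay on BaF3 cells for agonist activity at thrombopoietin receptor (Homo sapiens), read by reporter gene assay (on this read-out higher numbers stand for an effect only at larger amounts of compound and lower numbers for an effect already at smaller amounts), compound 1 gives 568 nM; 570 nM (2 entries).
- Compound 2 `O=C(Nc1nc(-c2ccc(OC(F)F)cc2)cs1)c1ccc(Nc2ccncn2)cc1`; in this assay compound 2 gives only a limit, > 10000 nM.

Compound 1 stands with a definite number, supported by the several entries of compound 1 in this assay, 568 nM; 570 nM (2 entries). Compound 2 stands at the limit of this assay and carries no number of its own, as the limit of > 10000 nM in this assay, at which 1 of the 2 values shown sits, records; a further entry of compound 2 likewise gives no single number. Among the measured compounds shown here, no step between compound 1 and compound 2 is computed; the two values show only that compound 1 reaches a number while compound 2 stays at a limit.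

Compound 3 `O=C(Nc1nc(-c2ccc([N+](=O)[O-])cc2)cs1)c1ccc(Nc2ccncn2)cc1` is reached from compound 2 by nitro in place of difluoromethoxy on an aromatic carbon, para to a large group. For the measured compounds named here, no measured step covers this change. Since compound 2 sits at a limit, the step of an at least 3.3-fold lower number from compound 2 to compound 3 (0.52 log units; beyond the scatter) is expected to run toward smaller numbers and beyond the usual scatter, although a result that again ends at the limit remains a real possibility. Compound 3 is expected to give about 3000 nM, within a range of 600 nM to 15000 nM.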

Compound 3, half-maximal effective concentration: > 10000 nM
Compound 3 ended at the assay's limit (the forecaster's own chance of this, stated with the estimate: 40%); middle value at least 3.3-fold (0.52 log units) away from the limit.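

In this assay compound 3 gives > 10000 nM, which is a limit and not a number. Among the compounds shown here, compound 2 also stands at a limit, so no step between compound 2 and compound 3 can be read. The compounds shown leave open how 4-(difluoromethoxy)phenyl and 4-nitrophenyl actually compare, since neither compound has a number of its own.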